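Aryl variation at the carbinol carbon: cytotoxicity notes

This account rests on a few compounds, and the source may have more. Where it says the series, first, only, none or still open, it means among the compounds named here.

Measured so far in an ADME assay on C8166 cells (Homo sapiens) for cytotoxicity, read by MTT assay; a lower number here means that less compound is tolerated, a higher number that more compound is tolerated:
compound 1 `Cc1cc(S(N)(=O)=O)ccc1NC(=O)COc1ccc(Cl)cc1C(O)c1ccccc1C` gives 33900 nM
compound 2 `Cc1cc(S(N)(=O)=O)ccc1NC(=O)COc1ccc(Cl)cc1C(O)c1cccc([N+](=O)[O-])c1` gives 36900 nM
compound 3 `Cc1cc(S(N)(=O)=O)ccc1NC(=O)COc1ccc(Cl)cc1C(O)c1cc(Cl)ccc1Cl` gives 36200 nM

Compound 2 sits together with the other two: the steps of a 1.1-fold higher number from compound 1 to compound 2 (0.04 log units; within the scatter) and a 1.0-fold lower number from compound 2 to compound 3 (0.01 log units; within the scatter) are both inside the scatter, and so is a 1.1-fold higher number from compound 1 to compound 3 (0.03 log units; within the scatter). The three compounds differ only in the aryl group on a saturated chain carbon bound to an aromatic carbon and an oxygen on a saturated carbon, and none of these swaps moved the number.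

Compound 4 `Cc1cc(S(N)(=O)=O)ccc1NC(=O)COc1ccc(Cl)cc1C(O)c1ccc2ccccc2c1` extends this set: naphthalen-2-yl in place of 3-nitrophenyl on a saturated chain carbon bound to an aromatic carbon and an oxygen on a saturated carbon. Among the measured compounds shown here, no measured step adds a second aromatic ring at this position, so the three within-scatter swaps are the only guide. A step of a 1.0-fold lower number from compound 2 to compound 4 (0.01 log units; within the scatter) is therefore expected, none beyond the scatter. For compound 4 the expected value in this assay is 36000 nM, within 18000 nM to 72000 nM.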

Compound 4, half-maximal cytotoxic concentration: 15700 nM
Compound 4: the middle estimate sits 2.3-fold (0.36 log units) above what was measured; the whole stated range lies above it.
By their numbers in this assay, from the lowest: compound 4; then compounds 1, 3 and 2 (each within the scatter of the next).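

In this assay, the aryl group on this saturated chain carbon can matter after all: naphthalen-2-yl moves the number toward less compound tolerated against all three single-ring groups (a 2.4-fold lower number from compound 2 to compound 4 (0.37 log units; beyond the scatter); a 2.3-fold lower number from compound 3 to compound 4 (0.36 log units; beyond the scatter); a 2.2-fold lower number from compound 1 to compound 4 (0.33 log units; beyond the scatter)). Among the compounds shown here, the shift goes with the only group carrying two six-membered aromatic rings, so this rests on compound 4 alone. Nothing measured accounts for the shift.

Open, from the compounds shown here alone, is whether the fused second ring itself is what counts. Naphthalen-1-yl, quinolin-3-yl or cyclohexyl at this carbon would help to separate these readings.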